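This account rests on a few compounds, and the source may have more. Where it says the series, first, only, none or still open, it means among the compounds named here.

Values in a toxicity assay on the whole organism (J774 cells) for cytotoxicity, with Mus musculus as the target, read by MTT assay, with a stated time of 24 h, tested at 10 uM (a higher number here means a weaker effect of the compound at the concentration tested, a lower number a stronger effect), for the three measured compounds:

Compound 1, `CCCCCCCCCO[C@@H]1[C@@H](N)[C@@H](OCC(O)CNCCCO)O[C@H](CN)[C@H]1OCCCCCCCCC`: 89.9%
Compound 2, `CCCCCCCCCO[C@@H]1[C@@H](N)[C@@H](OCC(O)CNCCN)O[C@H](CN)[C@H]1OCCCCCCCCC`: 87.5%
Compound 3, `CCCCCCCCCO[C@@H]1[C@@H](N)[C@@H](OC[C@@H](O)CN)O[C@H](CN)[C@H]1OCCCCCCCCC`: 85.1%

All three share the same core and differ only in the side chain attached through oxygen. Compound 3 gives the lowest of the three numbers, but none of the gaps is beyond the scatter: a number 4.8 percentage points lower from compound 1 to compound 3 (within the scatter) and a number 2.4 percentage points lower from compound 2 to compound 3 (within the scatter), with a number 2.4 percentage points lower from compound 1 to compound 2 (within the scatter) between the other two. On these numbers the three compounds are indistinguishable in this assay.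

The next compound is compound 4, `C=CCO[C@H]1O[C@H](CN)[C@@H](OCCCCCCCCC)[C@H](OCCCCCCCCC)[C@H]1N`. Compared with compound 3 the change is vinyl in place of 2-amino-1-hydroxyethyl on a saturated chain carbon bound to an oxygen on a saturated carbon. The two measured steps that bear on this are those landing on compound 3, as both alter the same place on a saturated chain carbon bound to an oxygen on a saturated carbon: a number 4.8 percentage points lower from compound 1 to compound 3 (within the scatter) and a number 2.4 percentage points lower from compound 2 to compound 3 (within the scatter). Both lie within the scatter, so the side chain at this place has not moved the read-out so far. Among the compounds with values here, the change to compound 4 removes more of that chain than either of those steps, but there is no measured step here to suggest a direction.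

For compound 4 the expected step is therefore a number 1.1 percentage points lower from compound 3 to compound 4 (within the scatter), with the number in this assay estimated at 84%, range 68% to 96%.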

Compound 4, a percentage reported as activity, at one concentration (the size of the read-out at that concentration, not a potency): 91.4%
Beside the measured number, compound 4's estimate is 7.4 percentage points below it; the range from low to high includes it.
By their numbers in this assay, from the lowest: compounds 3, 2, 1 and 4 (each within the scatter of the next).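

In this assay, the side chain on a saturated chain carbon bound to an oxygen on a saturated carbon can lose both its amine and its hydroxyl without leaving the scatter: vinyl, which has no hydrogen-bond donor or acceptor, in place of 2-amino-1-hydroxyethyl gives a number 6.3 percentage points higher from compound 3 to compound 4 (within the scatter). The comparisons with the two longer side chains read the same way, with a number 3.9 percentage points higher from compound 2 to compound 4 (within the scatter) and a number 1.5 percentage points higher from compound 1 to compound 4 (within the scatter), so the amine and hydroxyl common to compound 1, compound 2 and compound 3 are not needed at this place for a read-out within the scatter of theirs. No measurement at hand accounts for this lack of separation.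

Still open, as far as these compounds go, is whether any group at this place can move the read-out beyond the scatter, for example a carboxylic acid or a long unbranched alkyl chain in place of vinyl. With one tested concentration and one cell line, these numbers also leave open whether the four side chains would separate under other conditions.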